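A few compounds are considered here, and "the series" means these few. Any claim that something is new, unique, unknown or untested is made for them only; others in the source may bear on it.

Measured so far in an ADME assay on MRC5 cells (Homo sapiens) for cytotoxicity, read by fluorescence and resazurin assay, with a stated time of 3 days; on this read-out lower numbers stand for stronger inhibition and higher numbers for weaker inhibition:

- compound 1 `Cc1cn(C2CCN(Cc3cccc(Oc4ccccc4)c3)CC2)c(=O)[nH]c1=O` gives "not determined" (no result reported)
- compound 2 `Cc1cn(C2CCN(Cc3cccc(Oc4cc(F)cc(F)c4)c3)CC2)c(=O)[nH]c1=O` gives > 64000 nM as a limit of the assay
- compound 3 `Cc1cn(C2CCN(Cc3cccc(Oc4ccncc4)c3)CC2)c(=O)[nH]c1=O` gives "not determined" (no result reported)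

Compound 3 has no single number here, so it offers no starting value. For compound 2 the record is the limit of > 64000 nM in this assay, at which 1 of the 3 values shown sits, and this is a limit, not a number.

Compound 4 `Cc1cn(C2CCN(Cc3cccc(Oc4cccc(OC(F)(F)F)c4)c3)CC2)c(=O)[nH]c1=O` is still to be measured. The structural change is 3-(trifluoromethoxy)phenyl in place of pyridin-4-yl on an oxygen on an aromatic ring and it puts 3-(trifluoromethoxy)phenyl in place of pyridin-4-yl on an oxygen on an aromatic ring.

Within the data shown here, no measured step exists. No step beyond the usual scatter is expected in this assay from the sole result, compound 2 at > 64000 nM as a limit.

For compound 4 the estimated value is 50000 nM with an expected range from 20000 nM to 64000 nM.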

Compound 4, half-maximal inhibitory concentration: 5260 nM
Compound 4: middle estimate off by 9.5-fold (0.98 log units), on the high side, and the stated range ends above it.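

In this assay, the ring on this oxygen is not a silent position: exchanging 3,5-difluorophenyl for 3-(trifluoromethoxy)phenyl gives an at least 12-fold lower number from compound 2 to compound 4 (1.08 log units; beyond the scatter). Compound 4 at 5260 nM holds the only single number among the compounds shown. Compound 2 is recorded only as a limit, so the true size of the step stays unknown: the limit of > 64000 nM in this assay, at which 1 of the 4 values shown sits.

Steps involving compound 1 or compound 3 cannot be read. From the compounds shown here alone, whether a methoxy group or a nitrile on that ring would also lower the number remains open.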